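This account rests on a few compounds, and the source may have more. Where it says the series, first, only, none or still open, it means among the compounds named here.

Measured so far:
compound 1 `O=c1[nH]/c(=N\OCCCc2ccc(F)cc2)ccn1[C@@H]1O[C@H](COP(=O)(O)OP(=O)(O)OP(=O)(O)O)[C@@H](O)[C@H]1O` — 547 nM
compound 2 `O=c1[nH]/c(=N\OCCCc2ccsc2)ccn1[C@@H]1O[C@H](COP(=O)(O)OP(=O)(O)OP(=O)(O)O)[C@@H](O)[C@H]1O` — 103 nM

In a functional assay on 1321-N1 cells for agonist activity at P2Y purinoceptor 2 (Homo sapiens), read by scintillation counting and inositol phosphate accumulation (a lower number here means that less compound is needed, a higher number that more compound is needed for the effect), compound 2 gives the lowest of the two numbers; its nearest neighbour, compound 1, stands at a distance of a 5.3-fold lower number from compound 1 to compound 2 (0.73 log units; beyond the scatter). Compound 3 `O=c1[nH]/c(=N\OCCCc2ccc3ccccc3c2)ccn1[C@@H]1O[C@H](COP(=O)(O)OP(=O)(O)OP(=O)(O)O)[C@@H](O)[C@H]1O` is not yet measured. It differs from compound 2 by naphthalen-2-yl in place of thiophen-3-yl on a saturated chain carbon, three bonds along the chain from an oxygen. Going by the values given here, only one measured step bears on this change: the swap of one aromatic ring for another on the same chain carbon, a 5.3-fold lower number from compound 1 to compound 2 (0.73 log units; beyond the scatter), which lowered the number by a modest amount. Nothing measured involves naphthalen-2-yl or a two-ring aromatic group, so that step gives only a loose guide to direction and size. The expectation for compound 3 is therefore a step near the scatter, estimated as a 1.9-fold higher number from compound 2 to compound 3 (0.29 log units; within the scatter), with wide uncertainty. Compound 3 is estimated at 200 nM in this assay, in a range from 50 nM to 800 nM.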

Compound 3, half-maximal effective concentration: 139 nM
Compound 3: middle estimate off by 1.4-fold (0.16 log units), on the high side; the range from low to high includes it.
By their numbers in this assay, from the lowest: compounds 2 and 3 (each within the scatter of the next); then compound 1.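

Working from this assay, a two-ring carbon aromatic group is accepted on this saturated chain carbon, since replacing thiophen-3-yl with naphthalen-2-yl leaves the number within the scatter (a 1.3-fold higher number from compound 2 to compound 3 (0.13 log units; within the scatter)), so the ring sulfur is not needed to keep the number at this level. Compared with 4-fluorophenyl, naphthalen-2-yl also lowers the number beyond the scatter (a 3.9-fold lower number from compound 1 to compound 3 (0.59 log units; beyond the scatter)), which leaves compound 1 apart from the other two and shows that a larger aromatic group does not by itself raise the number in this set. Nothing available explains why 4-fluorophenyl stands apart.

Still open, from the compounds shown here alone, is whether plain phenyl, without the fluorine, would sit with compound 1 or with the other two. Also open, going by these compounds, is how a shorter or longer chain, or an amine on the naphthalene ring, would behave.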